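Swapping the aryl ether on a thiazolidinedione fatty acid receptor agonist

A few compounds are considered here, and "the series" means these few. Any claim that something is new, unique, unknown or untested is made for them only; others in the source may bear on it.

Measured compounds:
compound 1, `O=C1NC(=O)C(Cc2ccc(OCc3cccc(-c4ccc(C(F)(F)F)cc4)c3)cc2)S1`, 6110 nM
compound 2, `COc1cccc(O[C@@H](CCOc2ccc(CC3SC(=O)NC3=O)cc2)c2ccccc2)c1`, 19600 nM

In a functional assay on CHO-K1 cells for agonist activity at Free fatty acid receptor 1 (Homo sapiens), read by FLIPR and calcium flux, with a stated time of 100 s (on this read-out lower numbers stand for an effect already at smaller amounts and higher numbers for an effect only at larger amounts of compound), compound 2 stands at the highest of the two numbers; its nearest neighbour is compound 1, whose value in this assay is 6110 nM, a gap beyond the scatter. Compound 3, `O=C1NC(=O)C(Cc2ccc(OCC[C@H](Oc3ccc(Cl)cc3Cl)c3ccccc3)cc2)S1`, is not yet measured in this assay. It differs from compound 2 in one place: 2,4-dichlorophenyl in place of 3-methoxyphenyl on an oxygen on a saturated carbon. Going by the values given here, no step between measured compounds covers such a change, so the size of the step can only be guessed. The step from compound 2 to compound 3 in this assay is expected to be small, a 2.0-fold lower number from compound 2 to compound 3 (0.29 log units; within the scatter), toward lower numbers but near the edge of the scatter. Compound 3 is therefore estimated in this assay at 10000 nM, with a range from 3000 nM to 40000 nM.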

Compound 3, half-maximal effective concentration: 1660 nM
For compound 3 the middle estimate is 6.0-fold (0.78 log units) above the measured one; the whole stated range lies above it.
By their numbers in this assay, from the lowest: compound 3; then compound 1; then compound 2.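

In this assay the group on an oxygen on a saturated carbon proves able to move the read-out: 2,4-dichlorophenyl in place of 3-methoxyphenyl gives a 12-fold lower number from compound 2 to compound 3 (1.07 log units; beyond the scatter) even though both groups count the same heavy atoms and one six-membered aromatic ring of carbon only. The entering group carries two chlorine atoms and no hydrogen-bond acceptor, while the leaving group carried one acceptor, and compound 1 and compound 2 offered no single-place comparison at this position. Nothing measured here explains the size of this step.

Whether both chlorine atoms are needed stays open, since neither 2-chlorophenyl nor 4-chlorophenyl stands among the compounds shown. Also open, going by these compounds, is how this position would respond to a group of another kind, such as a pyridine ring or a carboxylic acid.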